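Benzamido for acetamido on a series stuck at the limit

This account rests on a few compounds, and the source may have more. Where it says the series, first, only, none or still open, it means among the compounds named here.

In a functional assay on PC-3 cells (Homo sapiens) for inhibition, read by sulforhodamine B assay (on this read-out lower numbers stand for stronger inhibition of growth and higher numbers for weaker inhibition of growth), compound 1 `COc1ccccc1CN1CCC=C(CCC(=O)NO)C1=O` gives > 10000 nM as a limit of the assay and not a number. Compound 2 `CC(=O)Nc1ccc(CN2CCC=C(CCC(=O)NO)C2=O)cc1` reads > 10000 nM and this value is also only a limit. Compound 2 therefore offers no number from which to measure a step (evidence: the limit of > 10000 nM in this assay, at which 2 of the 3 values shown sit). Within the data shown here, compound 3 `O=C(CCC1=CCCN(CCCc2ccc(-c3ccccc3)cc2)C1=O)NO` is the only one with a number, at 3230 nM and it carries the largest side group of the three.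

Compound 4 `O=C(CCC1=CCCN(Cc2ccc(NC(=O)c3ccccc3)cc2)C1=O)NO` keeps the core of compound 2 and changes the acetamido to benzamido, with phenyl in place of methyl on a carbonyl carbon. Among the measured compounds shown here, no measured pair shows a comparable change, so the expectation rests on a single comparison: the larger side group of compound 3 goes with a measurable 3230 nM in this assay and a similar gain is tentatively expected here. The estimated step is an at least 1.6-fold lower number from compound 2 to compound 4 (0.22 log units; that floor lies within the scatter) and it is expected to run modestly towards stronger inhibition of growth. A further reading at the limit remains quite possible. For compound 4 the estimated value is 6000 nM with an expected range from 2000 nM to 14000 nM in this assay.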

Compound 4, concentration for 50% growth inhibition: > 10000 nM
Compound 4: a limit, no number; the forecaster's own chance of this, stated with the estimate: 40%; middle value at least 1.6-fold (0.22 log units) away from the limit.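

No step can be read between compound 2 and compound 4, as both readings are limits of the assay and not numbers: the limit of > 10000 nM in this assay, at which 3 of the 4 values shown sit.

On these data alone, what remains open is whether phenyl in place of methyl on a carbonyl carbon changes growth inhibition at all in this assay, and by how much.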